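A few compounds are considered here, and "the series" means these few. Any claim that something is new, unique, unknown or untested is made for them only; others in the source may bear on it.

Measured compounds in a functional assay on MDA-MB-231 cells (Homo sapiens) for cytotoxicity, read by MTT assay, with a stated time of 72 h; on this read-out higher numbers stand for weaker inhibition and lower numbers for stronger inhibition:
- compound 1, `CN(C)CCCNc1nc(-c2ccc(NC(=O)Nc3ccccc3F)cc2)nc2ccsc12`: 660 nM
- compound 2, `Cc1ccc(NC(=O)Nc2ccc(-c3nc(NCCCN(C)C)c4sc(Cl)c(Cl)c4n3)cc2)cc1`: 4980 nM
- compound 3, `CN(C)CCNc1nc(-c2ccc(NC(=O)Nc3ccccc3F)cc2)nc2ccsc12`: 600 nM

Compound 3 holds the lowest number of the three in this assay. Its nearest neighbour is compound 1, a 1.1-fold lower number from compound 1 to compound 3 (0.04 log units; within the scatter), so the two are not separable. Compound 2 stands far off; set against compound 3 its number is higher by a margin well beyond the scatter, but compound 2 differs from compound 3 in a chlorinated core and in the longer chain of compound 1 as well as in the aryl urea, so no single step can be read from that pair.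

Compound 4, `Cc1ccc(NC(=O)Nc2ccc(-c3nc(NCCN(C)C)c4sccc4n3)cc2)cc1`, is not yet measured. It differs from compound 3 by 4-methylphenyl in place of 2-fluorophenyl on an amide-type nitrogen. Going by the values given here, no measured step bears on this change: the only step in hand concerns the chain. Among the compounds with values here, compound 2 is the one measured compound carrying the 4-methylphenyl urea, and its high number leaves open a weaker result for compound 4, though the chlorinated core may account for part of it.

Compound 4 is therefore expected to give a somewhat higher number than compound 3, a 2.2-fold higher number from compound 3 to compound 4 (0.34 log units; beyond the scatter), with the estimate for compound 4 at 1300 nM and a range of 450 nM to 4000 nM reflecting the lack of a direct step.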

Compound 4, half-maximal inhibitory concentration: 2180 nM
Compound 4: the middle estimate sits 1.7-fold (0.22 log units) below what was measured, within the range that was stated.
By their numbers in this assay, from the lowest: compounds 3 and 1 (each within the scatter of the next); then compound 4; then compound 2.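

In this assay, going by these compounds alone, the group on the amide-type nitrogen is the first place where a change made in one place moves the number beyond the scatter (4-methylphenyl in place of 2-fluorophenyl, a 3.6-fold higher number from compound 3 to compound 4 (0.56 log units; beyond the scatter)). Within the data shown here, the only earlier step, on the chain, stayed within the scatter (a 1.1-fold lower number from compound 1 to compound 3 (0.04 log units; within the scatter)), so the series now shows a response at this position, though a modest one that rests on a single pair. Nothing measured here bears on why the number rises.

This step swaps the substituent and its ring position together, so it cannot say whether the fluorine, the methyl or the position carries the difference; 4-fluorophenyl, 2-methylphenyl or plain phenyl on the same urea, with the core and chain of compound 3, would pull these apart. Also open, going by these compounds, are whether the step holds with the longer chain of compound 1, and how a group of another kind on this ring, such as an amine or a carboxylic acid, would read.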